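Replacing an Azide with a Phenyltriazole on a Shared Core

The compounds below may be only part of what the source reports. "The series", "measured", "known", "first", "only" and "open" are said of these compounds alone.

Three compounds share one core and differ only in the group attached to a saturated chain carbon bound to an aromatic carbon. In a functional assay on HCT-116 cells (Homo sapiens) for cytotoxicity, read by MTT assay, with a stated time of 72 h (a higher number here means a weaker inhibitor, a lower number a stronger inhibitor), compound 1 `NS(=O)(=O)c1cc(-c2nnc(CN3CCN(Cc4ccccc4)CC3)o2)c(Cl)cc1SCc1ccccc1` gives 26000 nM, and compound 2 `NS(=O)(=O)c1cc(-c2nnc(CN3CCC(Cc4ccccc4)CC3)o2)c(Cl)cc1SCc1ccccc1` gives 19000 nM. Compound 3 `[N-]=[N+]=NCc1nnc(-c2cc(S(N)(=O)=O)c(SCc3ccccc3)cc2Cl)o1` gives 100000 nM, the highest number of the set and beyond the scatter from both others, so it is the weakest inhibitor here. Compound 4 `NS(=O)(=O)c1cc(-c2nnc(Cn3cc(-c4ccccc4)nn3)o2)c(Cl)cc1SCc1ccccc1` has not been measured; it differs from compound 3 by 4-phenyl-1H-1,2,3-triazol-1-yl in place of azido on a saturated chain carbon bound to an aromatic carbon. A larger group at this carbon looks favourable because compound 1 gives 26000 nM and compound 2 gives 19000 nM, both lower than compound 3. The expected step is a 3.3-fold lower number from compound 3 to compound 4 (0.52 log units; beyond the scatter), toward stronger inhibition and beyond the scatter. Compound 4 is therefore estimated at 30000 nM, with a likely range from 10000 nM to 100000 nM.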

Compound 4, half-maximal inhibitory concentration: 75000 nM
Beside the measured number, compound 4's estimate is 2.5-fold (0.40 log units) below it; the range from low to high includes it.
By their numbers in this assay, from the lowest: compounds 2 and 1 (each within the scatter of the next); then compounds 4 and 3 (each within the scatter of the next).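

In this assay, 4-phenyl-1H-1,2,3-triazol-1-yl in place of azido on a saturated chain carbon bound to an aromatic carbon gives a 1.3-fold lower number from compound 3 to compound 4 (0.12 log units; within the scatter), so the two compounds cannot be told apart. A much larger group at this carbon therefore does not by itself ensure a lower number. No available evidence explains this result.

Still open, from the compounds shown here alone, is whether dimethylamino at this carbon would give a number distinct from that of compound 3. Also open, going by these compounds, is how a carboxylic acid in place of the phenyl on the triazole would read.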